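The compounds below may be only part of what the source reports. "The series", "measured", "known", "first", "only" and "open" are said of these compounds alone.

Working notes on the series, a physicochemical assay for lipophilicity, at pH 7.4; a lower number here means a more polar compound, a higher number a more lipophilic compound.

Compound 1, `Cc1cc(C(=O)Nc2cccc(F)c2)nn1Cc1cc(Cl)ccc1OCc1ccccc1`, gives 2.8 in this assay. Compound 2, `Cc1cc(C(=O)Nc2ccccn2)nn1Cc1cc(Cl)ccc1OCc1ccccc1`, reaches only the limit of the assay, > 3.7, and no number. Compound 3, `Cc1cc(NC(=O)C2CCCO2)nn1Cc1cc(Cl)ccc1OCc1ccccc1`, likewise sits at a limit, > 3.7. The two readable steps both run upward: a number at least 0.90 log units higher from compound 1 to compound 2 (beyond the scatter), and a number at least 0.90 log units higher from compound 1 to compound 3 (beyond the scatter). The step between the two limit compounds, a step that the two limits leave unreadable from compound 2 to compound 3, cannot be sized. Compound 3 thus stands at the top of what this assay reports, a limit and not a number; where it truly lies beyond the limit of > 3.7 in this assay, at which 2 of the 3 values shown sit, is not known.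

Compound 4, `COC(=O)Nc1cc(C)n(Cc2cc(Cl)ccc2OCc2ccccc2)n1`, is the next entry. It differs from compound 3 in one place: methoxy in place of oxolan-2-yl on a carbonyl carbon. Within the data shown here, none of the measured steps exchanges these two groups, so no measured step bears directly on it; what is known is only that compound 3 sits at a limit. The expectation is therefore a downward step, a number at least 0.50 log units lower from compound 3 to compound 4 (beyond the scatter), and a value for compound 4 in this assay estimated at 3.2, between 2.6 and 3.8.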

Compound 4, distribution coefficient: > 3.7
Compound 4 was reported as a limit (the forecaster's own chance of this, stated with the estimate: 25%); middle value at least 0.50 log units away from the limit.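

In this assay compound 4 also gives a limit and not a number, > 3.7. Methoxy in place of oxolan-2-yl on a carbonyl carbon leaves the series at the limit, so this position reaches it with or without the five-membered ring, and the steps among compound 2, compound 3 and compound 4 cannot be read. The (methoxycarbonyl)amino group in place of (3-fluorophenyl)carbamoyl gives a number at least 0.90 log units higher from compound 1 to compound 4 (beyond the scatter), and compound 1 is now the only compound with a readable number: the limit of > 3.7 in this assay, at which 3 of the 4 values shown sit.

Going by these compounds, how far compound 3 and compound 4 lie past the limit stays open, so the change on this carbonyl carbon has no size. On these data alone, whether an amine such as dimethylamino or a longer chain such as butoxy in place of methoxy would give a readable number in this assay is also open.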